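The source may report more compounds than this note shows. Statements on the series, on what has been measured and on what is new or still open speak of the compounds shown alone.

Working notes on the series

Three compounds have been run in a functional assay on K562 cells (Homo sapiens), read by MTT assay, with a stated time of 72 h (a lower number here means a stronger inhibitor, a higher number a weaker inhibitor), so far. Compound 1 `Cc1ncnc2c1c(-c1cc3ccccc3o1)cn2[C@@H]1O[C@H](CO)[C@@H](O)[C@H]1O` gives 19500 nM. Compound 2 `Cc1nc(N)c2c(-c3cc4ccccc4o3)cn([C@@H]3O[C@H](CO)[C@@H](O)[C@H]3O)c2n1` gives 15700 nM; the two numbers lie within the scatter of each other, and the difference between the two cores of compound 1 and compound 2 is not broken down here. Compound 3 `Cc1ncnc2c1c(-c1ccsc1)cn2[C@@H]1O[C@H](CO)[C@@H](O)[C@H]1O` gives 320 nM.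

Among the measured compounds shown here, the only counted change among the measured compounds is thiophen-3-yl in place of 1-benzofuran-2-yl on an aromatic carbon, and it made a large step: a 61-fold lower number from compound 1 to compound 3 (1.78 log units; beyond the scatter).

Compound 4 `Cc1nc(N)c2c(-c3ccsc3)cn([C@@H]3O[C@H](CO)[C@@H](O)[C@H]3O)c2n1` is not yet measured. It carries the same change on the core of compound 2: thiophen-3-yl in place of 1-benzofuran-2-yl on an aromatic carbon. The place of the change is described in the same words for both pairs, so this is the same change, made once more.

For the measured compounds named here, the expectation for compound 4 rests on two things: the value of compound 2, 15700 nM, as the starting point, and the size of the step from compound 1 to compound 3, a 61-fold lower number from compound 1 to compound 3 (1.78 log units; beyond the scatter), as the only measured example of this change. Going by the values given here, only one example of the step exists, so the expected step is kept close to that one, with a wide range: the step estimated from compound 2 to compound 4 in this assay is a 52-fold lower number from compound 2 to compound 4 (1.72 log units; beyond the scatter). Compound 4 is therefore expected to give about 300 nM in this assay, with a range estimated from 100 nM to 1000 nM.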

Compound 4, half-maximal inhibitory concentration: > 20000 nM
Compound 4 ended at the assay's limit (the forecaster's own chance of this, stated with the estimate: 5%); middle value at least 66-fold (1.82 log units) away from the limit.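

The change of 1-benzofuran-2-yl to thiophen-3-yl did not behave alike on the two cores in this assay: the same change on two cores in this assay, a 61-fold lower number (1.78 log units; beyond the scatter) from compound 1 to compound 3 and an at least 1.2-fold higher number (0.10 log units; that floor lies within the scatter) from compound 2 to compound 4, at least 77-fold (1.89 log units) apart, beyond the scatter of two such steps

Compound 4 gives > 20000 nM, which is a limit of the assay and not a number.

Among the compounds shown here, the second step therefore reads only as a floor, an at least 1.2-fold higher number from compound 2 to compound 4 (0.10 log units; that floor lies within the scatter), so this shows that the large drop in the number seen on the core of compound 1 does not carry over to the core of compound 2, but it does not show how large the true step on that core is, nor, with only two pairs, whether either result holds for other cores.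

The compounds shown leave open which of the differences between the two cores separates the two outcomes, since no pair here isolates them. They also leave open how other groups would behave on an aromatic carbon of the five-membered aromatic ring with 1 nitrogen on each core, for example a phenyl, a furan-3-yl or a pyridin-3-yl ring, and whether any of these would give a measurable number on the core of compound 2.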